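This account rests on a few compounds, and the source may have more. Where it says the series, first, only, none or still open, it means among the compounds named here.

Three compounds have so far been measured in a functional assay, read by spectrophotometry, with a stated time of 30 min; a higher number here means a weaker inhibitor, a lower number a stronger inhibitor:

Compound 1, `COc1ccc(C(=O)ON=C2CC(c3ccc(O)c(OC)c3)N(C)C(c3ccc(O)c(OC)c3)C2)cc1`, gives 33000 nM.
Compound 2, `COc1ccc(C(=O)ON=C2CC(c3ccc(O)c(OC)c3)N(C)C(c3ccc(O)c(OC)c3)C2)c(OC)c1`, gives 41000 nM.
Compound 3, `COc1cc(C2CC(=NOC(=O)c3ccc(O)cc3)CC(c3ccc(O)c(OC)c3)N2C)ccc1O`, gives 15100 nM.

Compound 3 holds the lowest number of the three. The step of a 2.2-fold lower number from compound 1 to compound 3 (0.34 log units; beyond the scatter) and the step of a 2.7-fold lower number from compound 2 to compound 3 (0.43 log units; beyond the scatter) are both beyond the scatter, so compound 3 counts as the strongest inhibitor of this small set, while compound 1 and compound 2 sit within the scatter of each other, as the step of a 1.2-fold higher number from compound 1 to compound 2 (0.09 log units; within the scatter) shows.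

Compound 4, `COc1cc(C2CC(=NOC(=O)c3ccc(F)cc3)CC(c3ccc(O)c(OC)c3)N2C)ccc1O`, differs from compound 3 in one place: fluoro in place of hydroxy on an aromatic carbon. Going by the values given here, no measured step exchanges a hydroxy for a fluoro. The nearest guides are the step of a 2.7-fold lower number from compound 2 to compound 3 (0.43 log units; beyond the scatter), in which a 4-hydroxyphenyl on the carbonyl carbon brought a modest gain, and the step of a 2.2-fold lower number from compound 1 to compound 3 (0.34 log units; beyond the scatter), in which a hydroxy in place of a methoxy also gave a modest gain. Both point to the hydroxy of compound 3 as part of its advantage; replacing it with a fluoro, which carries no donor, is therefore expected to give back some of that gain and to return the number to about where compound 1 and compound 2 lie. Compound 4 is accordingly expected at 30000 nM, with a range of 12000 nM to 80000 nM. The step expected from this change is a 2.0-fold higher number from compound 3 to compound 4 (0.30 log units; within the scatter) in this assay.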

Compound 4, half-maximal inhibitory concentration: 141000 nM
Compound 4: the middle estimate sits 4.7-fold (0.67 log units) below what was measured; the measured number lies above the stated range.
By their numbers in this assay, from the lowest: compound 3; then compounds 1 and 2 (each within the scatter of the next); then compound 4.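

In this assay, fluoro in place of hydroxy at this place, para to a large group, gave a 9.3-fold higher number from compound 3 to compound 4 (0.97 log units; beyond the scatter), the largest step seen so far and a larger change than any earlier exchange on this ring. The result also goes beyond giving back the advantage of compound 3, since the change to fluoro from the methoxy of compound 1 gave a 4.3-fold higher number from compound 1 to compound 4 (0.63 log units; beyond the scatter) and the change from the 2,4-dimethoxyphenyl of compound 2 gave a 3.4-fold higher number from compound 2 to compound 4 (0.54 log units; beyond the scatter), which makes compound 4 the weakest inhibitor of the four. Compound 1 and compound 4 both lack the hydroxy at this place yet remain apart beyond the scatter, so the loss of the hydroxy alone does not describe the outcome, and the identity of the group that replaces it also matters.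

Nothing shown here gives a cause for these steps. On these data alone, it remains open whether an amine, a carboxylic acid or a chloro at this same place would read closer to compound 3 or to compound 4, and whether the same order would hold on a changed core.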